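The compounds below may be only part of what the source reports. "The series", "measured", "known", "first", "only" and "open" are said of these compounds alone.

Compound 1 `CC1(C)S[C@@H]2/C(=C\C(=O)c3ccco3)C(=O)N2[C@H]1C(=O)OC(c1ccccc1)c1ccccc1` is the starting point. In a functional assay on A-375 cells (Homo sapiens) for cytotoxicity, read by MTT assay, with a stated time of 48 h (a lower number here means a stronger inhibitor, a higher number a weaker inhibitor), compound 1 gives 26000 nM. Of the two compounds that return a number in this assay, compound 1 has the higher one. Its nearest neighbour is compound 2 `CC1(C)S[C@@H]2/C(=C\C(=O)OC(c3ccccc3)c3ccccc3)C(=O)N2[C@H]1C(=O)OC(c1ccccc1)c1ccccc1`, and in this assay compound 2 gives 9100 nM, a gap that goes beyond the scatter of repeated measurements. Compound 3 `COC(=O)/C=C1\C[C@H]2SC(C)(C)[C@H](C(=O)OC(c3ccccc3)c3ccccc3)N2C1=O` returns no number in this assay; for compound 3 the result is only a limit of the assay, > 100000 nM.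

Compound 4 `CC1(C)S[C@@H]2/C(=C\C(=O)c3ccc(F)cc3)C(=O)N2[C@H]1C(=O)OC(c1ccccc1)c1ccccc1` has not yet been measured. It differs from compound 1 in a single place: 4-fluorophenyl in place of furan-2-yl on a carbonyl carbon. Among the compounds with values here, no measured pair in this set shows the same change, so there is no measured step to lean on. The step that the estimate implies is a 1.0-fold lower number from compound 1 to compound 4 (0.02 log units; within the scatter), and it is expected to stay within the usual scatter, in no particular direction. Compound 4 is therefore expected to give about 25000 nM, with a range from 8000 nM to 80000 nM.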

Compound 4, half-maximal inhibitory concentration: 17800 nM
For compound 4 the middle estimate is 1.4-fold (0.15 log units) above the measured one, and the stated range covers the measured number.
By their numbers in this assay, from the lowest: compounds 2, 4 and 1 (each within the scatter of the next, the first and the last beyond it). At a limit, above all of these: compound 3.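

Moving from furan-2-yl to 4-fluorophenyl on this carbonyl carbon, in this assay, gives a 1.5-fold lower number from compound 1 to compound 4 (0.16 log units; within the scatter). A larger ring of carbon only, carrying a fluorine and lacking the furan oxygen, therefore reads the same as the furan within the scatter, so in this pair the furan oxygen is not required for this level of cytotoxicity. Nothing measured here explains why the two groups read alike.

Plain phenyl remains open, and it would show whether the fluorine contributes anything on its own or whether any aromatic ring on this carbonyl carbon serves equally well. Also open, as far as these compounds go, is what happens when the ring is replaced by a non-aromatic group, such as a methyl group or a simple amine, on the same carbon.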